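Adding One Fluoro Group to the Weaker Inhibitor

A few compounds are considered here, and "the series" means these few. Any claim that something is new, unique, unknown or untested is made for them only; others in the source may bear on it.

For the measured compounds named here, only two related compounds have been measured so far in a functional assay on the whole organism with Scenedesmus acutus as the target; on this read-out lower numbers stand for stronger inhibition and higher numbers for weaker inhibition. Compound 1 `CCCOC(=O)c1cc(N2C(=O)C3=C(CCCC3)C2=O)c(F)cc1Cl` gives 89.1 nM, while compound 2 `CCCCOC(=O)c1cc(N2C(=O)C3=C(CCCC3)C2=O)ccc1Cl` gives 3550 nM. Compound 2 therefore has the higher of the two numbers and is the weaker inhibitor, by a gap well beyond the usual scatter of repeat measurements.

Compound 3 `CCCCOC(=O)c1cc(N2C(=O)C3=C(CCCC3)C2=O)c(F)cc1Cl` is compound 2 with a single alteration: fluoro in place of hydrogen on an aromatic carbon. Going by the values given here, the two measured compounds differ in more than one place, so no measured step isolates this alteration, and the gap between them cannot be assigned to any single feature. Among the compounds with values here, still, compound 1 also carries a fluoro group and gives 89.1 nM, which is the only guide available.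

A large step towards stronger inhibition, beyond the scatter, is therefore expected in this assay, though its size is uncertain. The expected change is the step of a 24-fold lower number from compound 2 to compound 3 (1.37 log units; beyond the scatter). The estimate for compound 3 is 150 nM, with a likely range from 40 nM to 600 nM.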

Compound 3, half-maximal inhibitory concentration: 67.6 nM
Beside the measured number, compound 3's estimate is 2.2-fold (0.35 log units) above it; the measured number falls inside the stated range.
By their numbers in this assay, from the lowest: compounds 3 and 1 (each within the scatter of the next); then compound 2.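

In this assay, for the compounds shown here, fluoro in place of hydrogen on this aromatic carbon, ortho to a large group and para to a butoxycarbonyl group, gives a 53-fold lower number from compound 2 to compound 3 (1.72 log units; beyond the scatter) and is a large step towards stronger inhibition; this is the first pair to isolate the change, which the two earlier compounds could not do because they differed in more than one place. With the fluoro group present, the length of the chain matters little in this pair: methyl in place of hydrogen on the saturated chain carbon gives a 1.3-fold lower number from compound 1 to compound 3 (0.12 log units; within the scatter) and stays within the scatter, so the two fluoro compounds cannot be ranked. Nothing measured here explains the size of the fluoro step.

As far as these compounds go, whether a methoxy group, a nitrile or a chloro group on this same carbon would match fluoro remains open. From the compounds shown here alone, it is also open whether a longer chain, such as pentyloxycarbonyl, would keep this level of inhibition, and whether the chain length would matter more in a compound with hydrogen on this carbon.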